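A Trifluoromethyl Exchange on the Shared Core

The source may report more compounds than this note shows. Statements on the series, on what has been measured and on what is new or still open speak of the compounds shown alone.

Among the compounds with values here, in a functional assay on HeLa cells (Homo sapiens) for antiproliferative activity, read by MTT assay, with a stated time of 48 h (a higher number here means a weaker inhibitor, a lower number a stronger inhibitor), compound 1 (`COc1ccc(-c2nn(-c3ccccc3)cc2-c2nc3cc(Cl)ccc3[nH]2)cc1`) gives 1290 nM and compound 2 (`COc1ccc(-c2nn(-c3ccccc3)cc2-c2nc3cc(OC)ccc3[nH]2)cc1`) gives 1140 nM so compound 2 stands level with the only other measured compound. Compound 3 (`COc1ccc(-c2nn(-c3ccccc3)cc2-c2nc3cc(C(F)(F)F)ccc3[nH]2)cc1`) carries trifluoromethyl in place of methoxy on an aromatic carbon. Within the data shown here, the only measured step bearing on this change is a 1.1-fold lower number from compound 1 to compound 2 (0.05 log units; within the scatter) and it brought methoxy in place of chloro without leaving the scatter. A similarly small step in no clear direction is therefore expected in this assay and the estimate is a 1.1-fold higher number from compound 2 to compound 3 (0.02 log units; within the scatter) within the scatter. Compound 3 is estimated at 1200 nM with an expected range from 500 nM to 3000 nM around that value.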

Compound 3, half-maximal inhibitory concentration: 2760 nM
Compound 3: the middle estimate sits 2.3-fold (0.36 log units) below what was measured; measured number inside the range.
By their numbers in this assay, from the lowest: compounds 2 and 1 (each within the scatter of the next); then compound 3.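

The exchange shows that this position of the shared core is not indifferent to its substituent in this assay, although chloro and methoxy could not be told apart there. Trifluoromethyl gives a 2.4-fold higher number from compound 2 to compound 3 (0.38 log units; beyond the scatter) and a 2.1-fold higher number from compound 1 to compound 3 (0.33 log units; beyond the scatter), both modest but beyond the scatter, which places compound 3 as the weakest of the three. Nothing measured here accounts for this difference. Still open, from the compounds shown here alone, is how an amine, a hydroxyl or a longer chain would fare at this position. Also open, going by these compounds, is whether trifluoromethyl would give a step of like size elsewhere on the shared core.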